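The source may report more compounds than this note shows. Statements on the series, on what has been measured and on what is new or still open speak of the compounds shown alone.

Working notes on the series.

Within the data shown here, compound 3 `COc1ccc(N2C(=O)N(Cc3ccccc3)c3ccccc3S2(=O)=O)cc1OC` stands highest of the three numbers so far: in an assay on isolated protein for displacement of a labelled ligand from Orexin/Hypocretin receptor type 1 (Homo sapiens), with a stated time of 90 min (on this read-out lower numbers stand for stronger inhibition and higher numbers for weaker inhibition), compound 3 gives 2000 nM. Compound 1 `COc1ccc(N2C(=O)N(Cc3c(F)cc(F)cc3F)c3ccccc3S2(=O)=O)cc1OC` gives 50.1 nM in this assay, and compound 2 `COc1ccc(N2C(=O)N(Cc3c(F)cc(F)cc3OC)c3ccccc3S2(=O)=O)cc1OC` gives 63.1 nM. The two substituted benzyl compounds sit close to each other, with a 1.3-fold higher number from compound 1 to compound 2 (0.10 log units; within the scatter), whereas the unsubstituted benzyl compound 3 lies far off: a 40-fold higher number from compound 1 to compound 3 (1.60 log units; beyond the scatter) and a 32-fold higher number from compound 2 to compound 3 (1.50 log units; beyond the scatter).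

Compound 4 `COc1cc(F)c(CN2C(=O)N(c3ccc(OC)c(OC)c3)S(=O)(=O)c3ccccc32)c(Cl)c1` is not yet measured. The change from compound 3 is 2-chloro-6-fluoro-4-methoxyphenyl in place of phenyl on a saturated chain carbon bound to an amide-type nitrogen in a ring. The two measured steps that bear on this are those from the substituted benzyl groups to plain benzyl, both large, both beyond the scatter, and both in the same direction. Compound 4 carries a ring substituted at the same kind of positions as compound 1 and compound 2, so a large step back down in this assay is expected, of a size comparable to those two steps, though with the chloro and the different methoxy placement the exact size is uncertain. For compound 4 the expected step is a 25-fold lower number from compound 3 to compound 4 (1.40 log units; beyond the scatter), so compound 4 is estimated at 80 nM, with a range from 25 nM to 250 nM.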

Compound 4, inhibition constant: 0.398 nM
For compound 4 the middle estimate is 200-fold (2.30 log units) above the measured one, and the stated range ends above it.
By their numbers in this assay, from the lowest: compound 4; then compounds 1 and 2 (each within the scatter of the next); then compound 3.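

At this place, on a saturated chain carbon bound to an amide-type nitrogen in a ring, 2-chloro-6-fluoro-4-methoxyphenyl gives in this assay a 5000-fold lower number from compound 3 to compound 4 (3.70 log units; beyond the scatter) and so reaches far beyond the gain seen with compound 1 and compound 2. Substitution on this ring therefore does not act as a single on-or-off change: compound 1 and compound 2 sit within the scatter of each other, yet the new group stands clear of both, with a 160-fold lower number from compound 2 to compound 4 (2.20 log units; beyond the scatter) and a 130-fold lower number from compound 1 to compound 4 (2.10 log units; beyond the scatter). No measurement on these compounds offers an explanation for these steps.

No pair shown separates the contribution of the chloro from that of the methoxy within the 2-chloro-6-fluoro-4-methoxyphenyl group. Also open, going by these compounds, is how this place responds to a group of another kind on the ring, such as an amine or a carboxylic acid.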